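This account rests on a few compounds, and the source may have more. Where it says the series, first, only, none or still open, it means among the compounds named here.

For the measured compounds named here, compound 2 `FC(F)(F)c1ccc(C2CC(c3ccc(Cl)cc3)=NN2c2ccc(-c3ccccc3)nn2)cc1` is the one compound with a number here: in a functional assay on Caco-2 cells (Homo sapiens) for antiproliferative activity, read by MTT assay, with a stated time of 24 h (a lower number here means a stronger inhibitor, a higher number a weaker inhibitor), compound 2 gives 10000 nM. Compound 1 `COc1ccc(C2CC(c3ccccc3)=NN2c2ccc(-c3ccccc3)nn2)c(OC)c1`, which carries the 2,4-dimethoxyphenyl group, reaches only (the limit of > 100000 nM in this assay, at which 1 of the 2 values shown sits), a limit of this assay rather than a number; in this assay compound 1 stands at > 100000 nM. Compound 3 `COc1ccc(C2CC(c3ccc(Cl)cc3)=NN2c2ccc(-c3ccccc3)nn2)c(OC)c1` joins the 4-chlorophenyl group of compound 2 with that same group: 2,4-dimethoxyphenyl in place of 4-(trifluoromethyl)phenyl on a saturated ring carbon. The step of a 4.0-fold higher number from compound 2 to compound 3 (0.60 log units; beyond the scatter) is expected to run toward weaker inhibition, beyond the scatter. Compound 3 is therefore estimated at 40000 nM in this assay, within 10000 nM to 150000 nM.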

Compound 3, half-maximal inhibitory concentration: > 100000 nM
Compound 3 was reported as a limit (the forecaster's own chance of this, stated with the estimate: 40%); at least 2.5-fold (0.39 log units) between middle value and limit.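

With the 4-chlorophenyl group held fixed, 2,4-dimethoxyphenyl in place of 4-(trifluoromethyl)phenyl on a saturated ring carbon gives, in this assay, an at least 10-fold higher number from compound 2 to compound 3 (1.00 log units; beyond the scatter). The chloro in place of hydrogen on an aromatic carbon cannot be read as a step, as both of its values are limits. Compound 1 and compound 3 share the same limit, not a number: the limit of > 100000 nM in this assay, at which 2 of the 3 values shown sit.

The compounds shown leave open whether a phenyl group carrying a single methoxy group, or an amine in place of the 2,4-dimethoxyphenyl group, would hold a number near that of compound 2.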